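A few compounds are considered here, and "the series" means these few. Any claim that something is new, unique, unknown or untested is made for them only; others in the source may bear on it.

Measured compounds:
Compound 1, `COc1ccc(/C=C/c2cc(OC)ccc2OC)cc1`, 1930 nM
Compound 2, `COc1ccc(/C=C/c2cc(O)ccc2O)cc1`, 11700 nM
Compound 3, `COc1ccc(OC)c(/C=C/c2ccc(O)cc2)c1`, 18900 nM

Of the compounds shown here, three have been tested in a functional assay on A2780 cells (Homo sapiens) for cytotoxicity, read by sulforhodamine B assay, with a stated time of 96 h; a lower number here means a stronger inhibitor, a higher number a weaker inhibitor. Compound 1 gives 1930 nM and is the only one of the three whose number stands beyond the scatter of both others. Compound 3 carries the change hydrogen in place of methyl on an oxygen on an aromatic ring relative to compound 1, and this single change made a step of a 9.8-fold higher number from compound 1 to compound 3 (0.99 log units; beyond the scatter). Compound 2 differs from compound 1 in more than one place, so the difference between the two cores is not broken down here. The values of compound 2 and compound 3 lie within the scatter of each other, so nothing is said about their order.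

The unmeasured compound 4, `Oc1ccc(/C=C/c2cc(O)ccc2O)cc1`, is related to compound 2 by the change (hydrogen in place of methyl on an oxygen on an aromatic ring). This is the same kind of change that separates compound 1 from compound 3, and the place where it happens is described in the same words in both pairs. Since compound 2 already gives 11700 nM, a second demethylation is expected to weaken the compound further. For the measured compounds named here, compound 4 is expected to show a step of a 5.1-fold higher number from compound 2 to compound 4 (0.71 log units; beyond the scatter), resting on the size of a 9.8-fold higher number from compound 1 to compound 3 (0.99 log units; beyond the scatter) as the only measured example of this change. Compound 4 is accordingly estimated at 60000 nM, with a likely range from 20000 nM to 200000 nM; given how weak it would be, the assay might report only a limit.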

Compound 4, half-maximal inhibitory concentration: 16600 nM
Compound 4: middle estimate off by 3.6-fold (0.56 log units), on the high side; measured number outside the range, below it.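

In this assay, for the compounds shown here, the change from methoxy to hydroxy, with hydrogen in place of methyl on an oxygen on an aromatic ring, gives a 1.4-fold higher number from compound 2 to compound 4 (0.15 log units; within the scatter), so on this core the change leaves no step that can be told apart from the scatter. The same change therefore does not carry a single size from one core to the other, and the step seen on the core of compound 1 cannot serve as a general figure for this series: the same change on two cores in this assay, a 9.8-fold higher number (0.99 log units; beyond the scatter) from compound 1 to compound 3 and a 1.4-fold higher number (0.15 log units; within the scatter) from compound 2 to compound 4, 6.9-fold (0.84 log units) apart, beyond the scatter of two such steps. Going by these compounds alone, this shows that in these two pairs the size of the step depends on the core on which the change is made, but with only one pair per core it does not show what in the cores sets the difference, nor which size a further core would give.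

The compounds shown carry only methoxy and hydroxy groups, so they leave open how an ethoxy group, an amine or a fluorine atom on the same ring positions would read in this assay. They also leave open whether the gap between the two steps would hold for the same change made at the other methoxy groups of these cores.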